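This account rests on a few compounds, and the source may have more. Where it says the series, first, only, none or still open, it means among the compounds named here.

In a functional assay on MCF7 cells (Homo sapiens) for cytotoxicity, read by MTT assay, with a stated time of 2 days, tested at 100 uM (a higher number here means a weaker effect of the compound at the concentration tested, a lower number a stronger effect), compound 1, `COc1ccc(-c2cc(C(C)=O)c3[nH]c(-c4ccccc4)cc3c2)cc1`, gives 30.8%. Compound 2, `COc1ccc(-c2cc(C(C)=O)c3[nH]c(-c4ccc(F)cc4)cc3c2)cc1`, differs from it only by fluoro in place of hydrogen on an aromatic carbon, and in this assay compound 2 gives 14.8%, a step of a number 16 percentage points lower from compound 1 to compound 2 (beyond the scatter).

Compound 3, `COc1ccc(-c2cc3cc(-c4ccccc4)cc(C(C)=O)c3[nH]2)cc1`, is built from the same atoms as compound 1 but joined differently; how the two cores differ is not broken down here. In this assay compound 3 gives 43.5%, the highest of the three numbers.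

Compound 4, `COc1ccc(-c2cc3cc(-c4ccc(F)cc4)cc(C(C)=O)c3[nH]2)cc1`, has not yet been measured. It stands to compound 3 as compound 2 stands to compound 1: fluoro in place of hydrogen on an aromatic carbon. Since the place is the same, this is the same change seen once before.

Among the measured compounds shown here, the step is expected to be a number 15.5 percentage points lower from compound 3 to compound 4 (beyond the scatter), resting on the one earlier example, a number 16 percentage points lower from compound 1 to compound 2 (beyond the scatter). Compound 4 is therefore estimated at 28%, between 15% and 41%.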

Compound 4, a percentage reported as activity, at one concentration (the size of the read-out at that concentration, not a potency): 47%
Beside the measured number, compound 4's estimate is 19 percentage points below it; the measured number lies above the stated range.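

Carried to the second core, the change from phenyl to 4-fluorophenyl gives a number 3.5 percentage points higher from compound 3 to compound 4 (within the scatter) in this assay. The two cores therefore do not respond alike to this change: the same change on two cores in this assay, a number 16 percentage points lower (beyond the scatter) from compound 1 to compound 2 and a number 3.5 percentage points higher (within the scatter) from compound 3 to compound 4, 19.5 percentage points apart, beyond the scatter of two such steps

This rests on one pair of compounds per core, tested at a single concentration, so it shows that the result of adding this fluoro depends on the core in these compounds, but not why it does, or whether the same would hold for other changes. The compounds shown carry only hydrogen or fluoro at this place, so it remains open how a chloro group, an amine or a carboxylic acid would behave there. Going by these compounds, whether such groups would also respond differently on the two cores remains open as well.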